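Working notes: from benzyl to 4-fluorobenzyl in the series

The source may report more compounds than this note shows. Statements on the series, on what has been measured and on what is new or still open speak of the compounds shown alone.

Compound 1 `Cc1ccc(S(=O)(=O)Oc2ccccc2/C=C(\C#N)C(=O)Nc2nnc(C)s2)cc1`: 33%
Compound 2 `Cc1ccc(S(=O)(=O)Oc2ccccc2/C=C(\C#N)C(=O)Nc2nnc(Cc3ccccc3)s2)cc1`: 69%

In a functional assay on RS4-11 cells (Homo sapiens) for inhibition, read by CCK-8 assay, with a stated time of 48 h, tested at 20 uM (on this read-out higher numbers stand for more inhibition of growth at the one concentration tested and lower numbers for less inhibition of growth), compound 2 holds the higher of the two numbers, at 69%, and compound 1 gives 33%. The next structure is compound 3 `Cc1ccc(S(=O)(=O)Oc2ccccc2/C=C(\C#N)C(=O)Nc2nnc(Cc3ccc(F)cc3)s2)cc1`. The change is fluoro in place of hydrogen on an aromatic carbon, which is fluoro in place of hydrogen on an aromatic carbon.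

Within the data shown here, only one measured step bears on this, and only indirectly. It is a number 36 percentage points higher from compound 1 to compound 2 (beyond the scatter), a large rise on placing phenyl in place of hydrogen on a saturated chain carbon bound to an aromatic carbon. That step adds a whole ring, whereas the new change adds a single fluorine to that ring. Among the measured compounds shown here, no fluoro step has been measured, so the size of the earlier step does not carry over. No step beyond the scatter is expected in this assay, and no firm direction can be given.

The expected step is a number 2 percentage points higher from compound 2 to compound 3 (within the scatter). For compound 3 the estimated value is 71%, with an expected range of 55% to 85%.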

Compound 3, percent growth inhibition at one concentration: 72%
For compound 3 the middle estimate is 1 percentage points below the measured one; the measured number falls inside the stated range.
By their numbers in this assay, from the lowest: compound 1; then compounds 2 and 3 (each within the scatter of the next).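

In this assay, the change from benzyl to 4-fluorobenzyl gives a number 3 percentage points higher from compound 2 to compound 3 (within the scatter), so fluoro on this aromatic carbon, para to a large group, is accepted without a step that can be told from the scatter. The large rise over the methyl-bearing compound 1 also survives on the substituted ring, at a number 39 percentage points higher from compound 1 to compound 3 (beyond the scatter), which stands alongside the earlier a number 36 percentage points higher from compound 1 to compound 2 (beyond the scatter); among the compounds shown, both the benzyl and the 4-fluorobenzyl groups carry that large rise. Nothing available explains either the large rise or the absence of a clear fluoro step.

With fluoro as the only substituent shown on this ring, it remains open whether a methoxy group, an amine or a carboxylic acid at the same place would leave the number unchanged, and whether a longer chain between the ring and the core of compound 2 would hold the rise. Since each number comes from one concentration, the read-out also leaves open whether compound 2 and compound 3 would separate at lower concentrations.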